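The compounds below may be only part of what the source reports. "The series", "measured", "known", "first", "only" and "open" are said of these compounds alone.

Three chalcone-like amides sharing one core have been measured in a functional assay on HeLa cells (Homo sapiens) for cytotoxicity, read by MTT assay, with a stated time of 72 h; on this read-out higher numbers stand for weaker inhibition and lower numbers for stronger inhibition. Compound 1 `COc1ccc(/C=C/C(=O)Nc2cc(C(=O)c3cc(OC)c(OC)c(OC)c3)cc(OC)c2OC)cc1OC` gives 2700 nM. Compound 2 `COc1ccc(/C=C/C(=O)Nc2cc(C(=O)c3cc(OC)c(OC)c(OC)c3)cc(OC)c2OC)cc1` gives 11200 nM, and compound 3 `COc1cccc(/C=C/C(=O)Nc2cc(C(=O)c3cc(OC)c(OC)c(OC)c3)cc(OC)c2OC)c1` gives 6900 nM. The steps of a 4.1-fold higher number from compound 1 to compound 2 (0.62 log units; beyond the scatter) and a 2.6-fold higher number from compound 1 to compound 3 (0.41 log units; beyond the scatter) are both modest, while a 1.6-fold lower number from compound 2 to compound 3 (0.21 log units; within the scatter) is within the scatter. Compound 3 therefore stands second highest of the three numbers, close to compound 2 and separated from compound 1 only by a modest step.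

Compound 4 `C#CCOc1cccc(/C=C/C(=O)Nc2cc(C(=O)c3cc(OC)c(OC)c(OC)c3)cc(OC)c2OC)c1` differs from compound 3 by ethynyl in place of hydrogen on a saturated chain carbon bound to an oxygen on an aromatic ring. Among the compounds with values here, none of the measured steps bears on this change: each of them removes a methoxy or moves it on the ring, and no measured pair extends an alkoxy chain. With nothing in the data to guide it, the expectation for the step of a 1.1-fold lower number from compound 3 to compound 4 (0.03 log units; within the scatter) is one that stays within the scatter in either direction. Compound 4 is accordingly expected to give about 6500 nM, with a range from 2200 nM to 20000 nM in this assay.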

Compound 4, half-maximal inhibitory concentration: 7300 nM
Compound 4: the middle estimate sits 1.1-fold (0.05 log units) below what was measured, within the range that was stated.
By their numbers in this assay, from the lowest: compound 1; then compounds 3, 4 and 2 (each within the scatter of the next).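

In this assay, replacing a hydrogen on the methoxy carbon of the 3-methoxyphenyl with ethynyl, which turns methoxy into propargyloxy, leaves the number within the scatter (a 1.1-fold higher number from compound 3 to compound 4 (0.02 log units; within the scatter)), so this position accepts the larger 3-(propargyloxy)phenyl group without a measurable change. Compound 4 also keeps the standing of compound 3 among the others: the gap to the 4-methoxyphenyl compound lies within the scatter (a 1.5-fold lower number from compound 2 to compound 4 (0.19 log units; within the scatter)), while the 3,4-dimethoxyphenyl compound remains modestly apart (a 2.7-fold higher number from compound 1 to compound 4 (0.43 log units; beyond the scatter)). Nothing at hand explains this result.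

Going by these compounds, whether a longer chain, an amine or a carboxylic acid at this end of the alkoxy chain would stay as close to compound 3 remains open. So does whether propargyloxy, exchanged for a methoxy on compound 1, would hold the number of compound 1 (2700 nM).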